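This account rests on a few compounds, and the source may have more. Where it says the series, first, only, none or still open, it means among the compounds named here.

Measured in an ADME assay on PC-3 cells (Homo sapiens) for cytotoxicity, read by CCK-8 assay, with a stated time of 6 days; on this read-out higher numbers stand for weaker inhibition and lower numbers for stronger inhibition:
- Compound 1 `C[C@@H](Cn1ccc(-c2ccc(C#N)c(Cl)c2)n1)NC(=O)C1CC(=O)C1`: > 30000 nM
- Compound 2 `C[C@@H](Cn1ccc(-c2ccc(C#N)c(Cl)c2)n1)NS(=O)(=O)c1cn(C)cn1`: > 30000 nM

Compound 2 gives > 30000 nM, which is a limit of the assay and not a number. Compound 1 gives > 30000 nM, which is also a limit. For the measured compounds named here, the only measured step is a step that the two limits leave unreadable from compound 1 to compound 2, so it offers no size to carry forward. Compound 3 `C[C@@H](Cn1ccc(-c2ccc(C#N)c(Cl)c2)n1)Nc1cccnc1` has not yet been measured in this assay. It differs from compound 2 in one place, on an amine nitrogen: pyridin-3-yl in place of (1-methyl-1H-imidazol-4-yl)sulfonyl on an amine nitrogen. Because of the limit of > 30000 nM in this assay, at which 2 of the 2 values shown sit, there is no sign yet of what moves this read-out, so no clear shift in either direction is expected. The expected change is a number no higher from compound 2 to compound 3 (the limit leaves the size open). For compound 3 the estimate is 30000 nM, with an expected range from 12000 nM to 40000 nM, and the assay may well report only a limit again.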

Compound 3, half-maximal inhibitory concentration: > 30000 nM
Compound 3: only a limit was reported; the forecaster's own chance of this, stated with the estimate: 80%; the middle value sits exactly at the limit.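

Compound 3 gives > 30000 nM, which is a limit of the assay and not a number, and the steps to it from compound 1 and compound 2 cannot be read. The compounds shown leave open whether any change on the amine nitrogen can produce a measurable number in this assay.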